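The compounds below may be only part of what the source reports. "The series", "measured", "known", "first", "only" and "open" are said of these compounds alone.

Measured compounds:
Compound 1 `CCC(C)C(N)c1cc(C(F)(F)F)ccc1N1CCN(C(=O)CCc2ccc(Cl)cc2Cl)CC1`: 160 nM
Compound 2 `Cc1cccc(CCC(=O)N2CCN(c3ccc(C(F)(F)F)cc3[C@@H](N)CC(C)C)CC2)c1`: 2100 nM
Compound 3 `Cc1[nH]c2ccccc2c1CCC(=O)N1CCN(c2ccc(C(F)(F)F)cc2[C@@H](N)CC(C)C)CC1`: 1600 nM

All three were tested in an assay on HEK293 cells for displacement of a labelled ligand from Melanocortin receptor 4 (Homo sapiens); on this read-out higher numbers stand for weaker inhibition and lower numbers for stronger inhibition. Compound 1 gives the lowest of the three numbers; its gaps to compound 3 and to compound 2 both lie beyond the scatter, so it is the strongest binder among them. Compound 2 and compound 3 differ only at the end of the chain, and the step there is a 1.3-fold lower number from compound 2 to compound 3 (0.12 log units; within the scatter), which means that exchange made no real difference.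

Compound 4 `CCC(C)[C@H](NC(C)=O)c1cc(C(F)(F)F)ccc1N1CCN(C(=O)CCc2ccc(Cl)cc2Cl)CC1` differs from compound 1 in one place: 1-acetamido-2-methylbutyl in place of 1-amino-2-methylbutyl on an aromatic carbon. For the measured compounds named here, the only measured step concerns the group at the end of the chain, not this part of the molecule, so no measured step bears directly on this change. There is no information on how the acetamido group in place of the free amine affects binding, and the expectation can rest only on the value of compound 1 with a wide range around it. Compound 4 is therefore expected to give about 500 nM, with a range from 100 nM to 3000 nM. The expected step is a 3.1-fold higher number from compound 1 to compound 4 (0.49 log units; beyond the scatter), a change whose direction is uncertain.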

Compound 4, inhibition constant: 360 nM
Estimate against measurement, compound 4: 1.4-fold (0.14 log units) above; the range from low to high includes it.
By their numbers in this assay, from the lowest: compound 1; then compound 4; then compounds 3 and 2 (each within the scatter of the next).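

In this assay, adding an acetyl group to the free amine of compound 1 gives a 2.3-fold higher number from compound 1 to compound 4 (0.35 log units; beyond the scatter), a real but modest loss, so binding at this position does not depend on a free amine. Compound 4 still gives 360 nM, which shows that this position accepts the larger 1-acetamido-2-methylbutyl group, with its added carbonyl, at only that modest cost. The step also carries a difference in drawn structure, as the entering group has one defined stereocentre and the leaving group has none, and nothing at hand explains the step.

Going by these compounds, it remains open whether a smaller N-methyl amine or a longer acyl group, such as propanamide, would stay closer to compound 1. On these data alone, the mirror-image form of the acetamido carbon is also open, so the part played by that stereocentre cannot be separated from the part played by the acetyl group.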